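Benzimidazole substituent change: cyclopentyl to trifluoromethyl

The source may hold more compounds than are shown below. What is called first, only, known or untested is meant among the compounds shown, and "the series" means these compounds.

Measured so far:
compound 1 `CCCCOC(=O)NS(=O)(=O)c1ccc(CCC)cc1-c1ccc(Cn2c(-c3nccs3)nc3ccccc32)cc1`: 5.1 nM
compound 2 `CCCCOC(=O)NS(=O)(=O)c1ccc(CCC)cc1-c1ccc(Cn2c(C3CCCC3)nc3ccccc32)cc1`: 35 nM

Both compounds were tested in an assay on membranes from HEK293 cells for displacement of a labelled ligand from Type-2 angiotensin II receptor (Homo sapiens), read by radioligand binding; on this read-out higher numbers stand for weaker inhibition and lower numbers for stronger inhibition. Compound 1 gives 5.1 nM, and compound 2 gives 35 nM. Going by the values given here, the only step measured so far, a 6.9-fold higher number from compound 1 to compound 2 (0.84 log units; beyond the scatter), is the exchange of the group on the aromatic carbon of the fused five-membered ring. Among the compounds with values here, on these two numbers compound 2 stands highest; compound 1 lies at the lower number and is the only neighbour.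

Compound 3 `CCCCOC(=O)NS(=O)(=O)c1ccc(CCC)cc1-c1ccc(Cn2c(C(F)(F)F)nc3ccccc32)cc1` is not yet measured. It differs from compound 2 by trifluoromethyl in place of cyclopentyl on an aromatic carbon. Within the data shown here, the one measured step bears on it only loosely: it shows that the group at this position moves the number in this assay well beyond the scatter, but it compares two groups that both carry a ring, while the trifluoromethyl group carries none. Among the measured compounds shown here, no measured pair isolates a small non-ring group at this position.

Compound 3 is therefore expected to lie near compound 2, with wide uncertainty in either direction, estimated at 40 nM (range 10 nM to 160 nM). The expected step is a 1.1-fold higher number from compound 2 to compound 3 (0.06 log units; within the scatter).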

Compound 3, inhibition constant: 13 nM
Compound 3: the middle estimate sits 3.1-fold (0.49 log units) above what was measured; low and high end bracket the measured number.
By their numbers in this assay, from the lowest: compound 1; then compound 3; then compound 2.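

In this assay, a ring is not required on the aromatic carbon between two ring nitrogen atoms: the exchange of cyclopentyl for trifluoromethyl gives a 2.7-fold lower number from compound 2 to compound 3 (0.43 log units; beyond the scatter) and so improves on the larger carbon ring. The 1,3-thiazol-2-yl group still keeps the lowest number of the three, since replacing it with trifluoromethyl gives a 2.5-fold higher number from compound 1 to compound 3 (0.41 log units; beyond the scatter), which places the two ring-bearing groups on either side of the ring-free one and shows that the presence of a ring alone does not set the order among these compounds. Nothing available on these compounds speaks to what lies behind this order.

Still open, on these data alone, is whether a plain ring-free alkyl group such as methyl or a longer chain such as butyl would follow trifluoromethyl on this carbon, and how an amine or a carboxylic acid would fare there. Going by these compounds alone, also open is whether another aromatic ring, such as phenyl or furan-2-yl, would match 1,3-thiazol-2-yl, the only aromatic group among the three.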